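The source may report more compounds than this note shows. Statements on the series, on what has been measured and on what is new or still open speak of the compounds shown alone.

Measured compounds:
compound 1, `C=C(Br)C(=O)Nc1ccc(/C=C2\SC(=O)N(Cc3ccc(Cl)cc3)C2=O)cc1`, 5100 nM
compound 2, `Nc1ccc(/C=C2\SC(=O)N(Cc3ccc(Cl)cc3)C2=O)cc1`, 60000 nM

In a functional assay on FM3A cells (Mus musculus) for cytotoxicity, read by cell counting, with a stated time of 2 days (a higher number here means a weaker inhibitor, a lower number a stronger inhibitor), compound 1 gives the lower of the two numbers. Compound 2 gives a higher number, and the step of a 12-fold higher number from compound 1 to compound 2 (1.07 log units; beyond the scatter) is the only one measured. Compound 3, `C=C(Br)C(=O)Nc1ccc(/C=C2\SC(=O)N(Cc3cccc(F)c3)C2=O)cc1`, keeps the shared core of compound 1 and changes it at one place only: 3-fluorophenyl in place of 4-chlorophenyl on a saturated chain carbon bound to an amide-type nitrogen in a ring. Cut one bond further out, the change reads 4-chlorobenzyl to 3-fluorobenzyl. Within the data shown here, the one measured step concerns a different part of the molecule, the group on a nitrogen on an aromatic ring, so nothing measured speaks to the exchange in compound 3. For compound 3 the expected step in this assay is therefore small, a 1.4-fold higher number from compound 1 to compound 3 (0.14 log units; within the scatter), lying within the scatter in either direction. Compound 3 is estimated at 7000 nM, with a range from 2500 nM to 20000 nM.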

Compound 3, half-maximal inhibitory concentration: 4000 nM
Compound 3: the middle estimate sits 1.8-fold (0.24 log units) above what was measured, and the stated range covers the measured number.
By their numbers in this assay, from the lowest: compounds 3 and 1 (each within the scatter of the next); then compound 2.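

In this assay, the exchange of 4-chlorobenzyl for 3-fluorobenzyl gives a 1.3-fold lower number from compound 1 to compound 3 (0.11 log units; within the scatter), a step that lies within the scatter. Among these compounds, this is the first reading at the saturated chain carbon bound to an amide-type nitrogen in a ring, and it shows that the halogen and its place on the phenyl ring can differ together without the number moving beyond the scatter, in contrast to the large step seen at the group on the aromatic nitrogen. No measured evidence is available that bears on this result.

From the compounds shown here alone, the two differences are made together here, so their separate contributions remain unknown, and either one alone might matter. Also open, going by these compounds, is how the number would respond to a plain benzyl without halogen, or to a small ethyl group in its place.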